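The compounds below may be only part of what the source reports. "The series", "measured", "known", "first", "only" and "open" are said of these compounds alone.

Compound 1 `O=C(NCC1CCCCC1)c1cccc(/C=C2\CC(=O)N(c3ccccc3)C2=O)c1` gives > 100000 nM in an ADME assay on SW480 cells (Homo sapiens) for cytotoxicity, read by MTT assay, with a stated time of 72 h (a lower number here means a stronger inhibitor, a higher number a weaker inhibitor), a limit of the assay.
Compound 2 `CCCCCN1C(=O)C/C(=C\c2cccc(C(=O)NCCCC)c2)C1=O` gives > 100000 nM, likewise a limit.
Compound 3 `Cc1ccc(NC(=O)c2cccc(/C=C3\CC(=O)N(c4ccccc4)C3=O)c2)cc1C` gives > 100000 nM, again a limit.

Compound 2 thus stands at the assay limit, as do the other two values shown, so this set gives no number for it. Compound 4 `CCCCCN1C(=O)C/C(=C\c2cccc(C(=O)Nc3ccc(OC)cc3)c2)C1=O` differs from compound 2 in one place: 4-methoxyphenyl in place of butyl on an amide-type nitrogen. Going by the values given here, the only step between measured compounds, a step that the two limits leave unreadable from compound 1 to compound 3, also exchanges a group on an amide-type nitrogen, but its size cannot be read because of the limit of > 100000 nM in this assay, at which 3 of the 3 values shown sit. No readable step therefore bears on the change to compound 4, and the expectation is that compound 4 remains at the limit too. Compound 4 is accordingly estimated at 150000 nM (range 50000 nM to 500000 nM). The step from compound 2 to compound 4 is expected to be a step that the limit leaves unreadable from compound 2 to compound 4, nothing beyond the scatter.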

Compound 4, half-maximal inhibitory concentration: > 100000 nM
Compound 4 ended at the assay's limit; the forecaster's own chance of this, stated with the estimate: 85%; the middle value does not contradict the limit.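

The step from compound 2 to compound 4 cannot be read, and compound 4 adds no comparison: the limit of > 100000 nM in this assay, at which 4 of the 4 values shown sit.
The compounds shown leave open whether any group on the amide-type nitrogen would give a readable number in this assay.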